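Swapping One Halogen for Another on a Chalcone

A few compounds are considered here, and "the series" means these few. Any claim that something is new, unique, unknown or untested is made for them only; others in the source may bear on it.

Of the compounds shown here, three have been tested in a toxicity assay on cells (Macrophage, Mus musculus, strain BALB/c) for cytotoxicity, read by MTT assay; on this read-out higher numbers stand for weaker inhibition and lower numbers for stronger inhibition. Compound 1 `C=CCOc1cc(OC)c(C(=O)/C=C/c2ccc(F)cc2)c(OCC=C)c1` gives 13800 nM. Compound 2 `COc1cc(O)cc(O)c1C(=O)/C=C/c1ccc(F)cc1` gives 28800 nM, and compound 3 `COc1cccc(/C=C/C(=O)c2c(O)cc(O)cc2OC)c1` gives 17600 nM. Compound 1 has the lowest number of the three. Its gap to compound 3 lies within the usual scatter of repeated measurements, so the two cannot be ranked against each other; its gap to compound 2 lies beyond that scatter, so compound 1 inhibits the cells more strongly than compound 2.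

Compound 4 `C=CCOc1cc(OC)c(C(=O)/C=C/c2ccc(Cl)cc2)c(OCC=C)c1` has not yet been measured. It differs from compound 1 in one place: chloro in place of fluoro on an aromatic carbon. Among the compounds with values here, none of the measured compounds differ from one another in a single place, so no measured step shows what such a swap does. The change is modest on paper: one heavy atom leaves and one enters, with no change in rings, hydrogen-bond donors, hydrogen-bond acceptors or charge. The step is therefore expected to stay within the scatter, with no clear direction, giving an expected 1.2-fold lower number from compound 1 to compound 4 (0.06 log units; within the scatter). Compound 4 is expected to give about 12000 nM, estimated to fall between 5500 nM and 26000 nM.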

Compound 4, half-maximal inhibitory concentration: 13000 nM
Estimate against measurement, compound 4: 1.1-fold (0.03 log units) below; the range from low to high includes it.
By their numbers in this assay, from the lowest: compounds 4, 1, 3 and 2 (each within the scatter of the next, the first and the last beyond it).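

Within the data shown here, compound 1 and compound 4 form the only pair that differs in a single place, so this is the one direct look at what a halogen swap does on the ring. In this assay, going from 4-fluorophenyl to 4-chlorophenyl gives a 1.1-fold lower number from compound 1 to compound 4 (0.03 log units; within the scatter), a step too small to separate from the noise of repeating the measurement. At this position, on an aromatic carbon para to a large group, fluoro and chloro therefore cannot be told apart on this read-out, and no supporting measurement is available to explain the outcome.

The compounds shown leave open what a group of a different kind, such as an amine, a carboxylic acid or a longer chain, would do at this same position, since the single step here covers only one halogen exchanged for another. On these data alone, it also remains open whether chloro in place of fluoro would read the same way on a different core, such as that of compound 2.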